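The compounds below may be only part of what the source reports. "The series", "measured", "known", "first", "only" and "open" are said of these compounds alone.

Compound 1 `O=C(Nc1nc(-c2ccccn2)cs1)c1ccc(Br)cc1` and compound 2 `O=C(Nc1nc(-c2ccccn2)cs1)c1ccc(Cl)cc1` and compound 3 `O=C(Nc1nc(-c2ccccn2)cs1)c1ccccc1F` share one core and differ only in the groups on a single ring. Among the compounds with values here, in an ADME assay on Vero cells (Chlorocebus sabaeus) for cytotoxicity, read by MTT assay, with a stated time of 72 h (a lower number here means that less compound is needed, a higher number that more compound is needed for the effect), compound 1 gives 4700 nM as its result, and this is the only real number in the set. Compound 2 is recorded as "not determined" (no result reported) in this assay and compound 3 is recorded as "not determined" (no result reported) there too. Within the data shown here, compound 3 therefore has no single number to serve as a starting point, and no measured step exists to learn from.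

Compound 4 `O=C(Nc1nc(-c2ccccn2)cs1)c1ccc(F)cc1F` has yet to be tested. It is reached through fluoro in place of hydrogen on an aromatic carbon in which fluoro takes the place of hydrogen on an aromatic carbon, para to a large group and meta to a fluoro group. Among the measured compounds shown here, with no measured pair to size such a change, the expectation in this assay is a step no larger than the usual scatter, with no favoured direction. For the measured compounds named here, the only anchor is compound 1 at 4700 nM in that test, so the estimate has to stay wide. Compound 4 is expected near 5000 nM with an estimated range from 1500 nM to 20000 nM once it is measured.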

Compound 4, half-maximal effective concentration: 7300 nM
Compound 4: the middle estimate sits 1.5-fold (0.16 log units) below what was measured, within the range that was stated.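

Compound 3 has no single number to set against compound 4, so the change between them, fluoro in place of hydrogen, cannot be read as a step. The compounds shown leave open how far, and in which direction, a fluoro group in that place moves the result. No supporting data bear on the value of compound 4.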